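The compounds below may be only part of what the source reports. "The series", "measured", "known", "first", "only" and "open" are said of these compounds alone.

Compound 1 `CCC(Nc1nnc(-c2ccc(OC)cc2)o1)[C@H]1CC[C@@H](c2ccnc3c(F)cc(F)cc32)CC1` is the starting point here. Among the compounds with values here, in an assay on tissue (HeLa cells) for inhibition of Indoleamine 2,3-dioxygenase 1 (Homo sapiens), read by fluorescence, with a stated time of 18 h (on this read-out lower numbers stand for stronger inhibition and higher numbers for weaker inhibition), compound 1 gives 3 nM, the lowest number among the two compounds measured so far. The other measured compound, compound 2 `COc1ccc(Nc2nnc([C@H](C)[C@H]3CC[C@@H](c4ccnc5ccc(F)cc54)CC3)o2)cc1`, carries a differently built side chain and a core with one fluoro group fewer; in this assay compound 2 gives 165 nM, a higher number than compound 1 by a gap that lies beyond the scatter of repeated measurements. Compound 3 `CCC(Nc1nnc(-c2ccc(OC)cc2)o1)[C@H]1CC[C@@H](c2ccnc3ccc(F)cc32)CC1` is the one still to be measured. It differs from compound 1 in a single place: hydrogen in place of fluoro on an aromatic carbon, on the core shared by both. Within the data shown here, no pair of measured compounds differs by just this change, so the size of its effect is unknown from these data. A small rise in the number, possibly none beyond the scatter, is expected for the step of a 2.3-fold higher number from compound 1 to compound 3 (0.37 log units; beyond the scatter). Compound 3 is therefore estimated at 7 nM, within a range of 2 nM to 25 nM.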

Compound 3, half-maximal inhibitory concentration: 6 nM
For compound 3 the middle estimate is 1.2-fold (0.07 log units) above the measured one; low and high end bracket the measured number.
By their numbers in this assay, from the lowest: compounds 1 and 3 (each within the scatter of the next); then compound 2.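

In this assay, within the data shown here, hydrogen in place of fluoro on the aromatic carbon ortho to a fused ring gives a 2.0-fold higher number from compound 1 to compound 3 (0.30 log units; within the scatter), the first direct reading of this change. The two numbers cannot be told apart, so with this side chain and this core, the fluoro group at this position makes no difference that this assay can resolve. No measurement here offers an explanation for this result.

Only hydrogen and fluoro are compared at this position, so a chloro, methyl, methoxy or amino group there could give a quite different number. Also open, on these data alone, is what the fluoro group that remains on the core of compound 3 contributes, and whether this result would hold with a different side chain.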